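Replacing the phenylsulfonyl group with a urea-bearing chain

The compounds below may be only part of what the source reports. "The series", "measured", "known", "first", "only" and "open" are said of these compounds alone.

Compound 3 `O=C(NS(=O)(=O)c1ccccc1)c1ccc(Nc2nc(NC3(c4ccc(Cl)cc4)CC3)nc(OCC(F)(F)F)n2)cc1` stands highest of the three measured compounds in a physicochemical assay for permeability, using PAMPA, at pH 7.4 (a higher number here means that the compound crosses the layer faster, a lower number that the compound crosses the layer more slowly), giving 182 nm/s. Compound 1 `CC(C)C(=O)NCCS(=O)(=O)NC(=O)c1ccc(Nc2nc(NC3(c4ccc(Cl)cc4)CC3)nc(OCC(F)(F)F)n2)cc1` gives 13 nm/s in this assay, and compound 2 `O=C(NS(=O)(=O)CCNC(=O)C1CC1)c1ccc(Nc2nc(NC3(c4ccc(Cl)cc4)CC3)nc(OCC(F)(F)F)n2)cc1` gives 1 nm/s. Compound 4 `CC(C)NC(=O)NCCS(=O)(=O)NC(=O)c1ccc(Nc2nc(NC3(c4ccc(Cl)cc4)CC3)nc(OCC(F)(F)F)n2)cc1` differs from compound 3 by 2-((isopropylcarbamoyl)amino)ethyl in place of phenyl on a sulfonyl sulfur. Among the measured compounds shown here, two measured steps bear on this change, both running the other way: a 14-fold higher number from compound 1 to compound 3 (1.15 log units; beyond the scatter) and a 180-fold higher number from compound 2 to compound 3 (2.26 log units; beyond the scatter), each large. The step of a 13-fold lower number from compound 1 to compound 2 (1.11 log units; beyond the scatter) shows that even a small alteration within such a chain moves the number considerably. A large downward step is therefore expected, and the estimated step is a 46-fold lower number from compound 3 to compound 4 (1.66 log units; beyond the scatter). Compound 4 is expected to give 4 nm/s in this assay, within a range from 1 nm/s to 15 nm/s.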

Compound 4, apparent permeability: 45 nm/s
Compound 4: middle estimate off by 11-fold (1.05 log units), on the low side; measured number above the stated range.
By their numbers in this assay, from the lowest: compound 2; then compound 1; then compound 4; then compound 3.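

In this assay, the 2-((isopropylcarbamoyl)amino)ethyl chain on the sulfonyl sulfur gives only a modest drop from phenyl, with a 4.0-fold lower number from compound 3 to compound 4 (0.61 log units; beyond the scatter) as the step, so a chain at this position need not cost as much as the two amide chains do. Isopropylamino on the carbonyl carbon gives a 3.5-fold higher number from compound 1 to compound 4 (0.54 log units; beyond the scatter) in place of isopropyl and a 45-fold higher number from compound 2 to compound 4 (1.65 log units; beyond the scatter) in place of cyclopropyl. No measurement here accounts for these steps.

From the compounds shown here alone, whether cyclopropylamino on that carbonyl carbon would behave like isopropylamino remains open, as does a chain bearing a carboxylic acid.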